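Shifting the Bromine Around the Anilide Ring

The compounds below may be only part of what the source reports. "The series", "measured", "known", "first", "only" and "open" are said of these compounds alone.

In a functional assay on MGC-803 cells (Homo sapiens) for inhibition, read by MTT assay, with a stated time of 72 h (on this read-out lower numbers stand for stronger inhibition and higher numbers for weaker inhibition), compound 2 `O=C(CSc1nc(Nc2ccccc2)c2ccccc2n1)Nc1cccc([N+](=O)[O-])c1` gives 28100 nM, the higher of the two numbers recorded, while compound 1 `O=C(CSc1nc(Nc2ccccc2)c2ccccc2n1)Nc1cccc(Br)c1` gives 9620 nM. Among the compounds with values here, the single measured step, a 2.9-fold higher number from compound 1 to compound 2 (0.47 log units; beyond the scatter), bears directly on the change that follows. Compound 3 `O=C(CSc1nc(Nc2ccccc2)c2ccccc2n1)Nc1ccc(Br)cc1` differs from compound 2 by 4-bromophenyl in place of 3-nitrophenyl on an amide-type nitrogen. That change reverses the bromo-to-nitro exchange and also relocates the bromine on the ring, a move for which no comparison exists. A fall of roughly the size seen for compound 1 is expected, giving a 2.8-fold lower number from compound 2 to compound 3 (0.45 log units; beyond the scatter). Compound 3 is therefore estimated at 10000 nM, with a range from 4000 nM to 25000 nM.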

Compound 3, half-maximal inhibitory concentration: 19300 nM
Beside the measured number, compound 3's estimate is 1.9-fold (0.29 log units) below it; low and high end bracket the measured number.
By their numbers in this assay, from the lowest: compounds 1, 3 and 2 (each within the scatter of the next, the first and the last beyond it).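

In this assay, within the data shown here, replacing 3-bromophenyl with 4-bromophenyl on the amide-type nitrogen gives a 2.0-fold higher number from compound 1 to compound 3 (0.30 log units; within the scatter), so the two bromine placements cannot be told apart, a comparison the earlier compounds did not offer. Exchanging 3-nitrophenyl for 4-bromophenyl gives a 1.5-fold lower number from compound 2 to compound 3 (0.16 log units; within the scatter), so the gap beyond the scatter seen earlier for nitro against bromo does not hold for this bromine placement. Nothing available accounts for these numbers. The compounds shown leave open how an amine or a carboxylic acid on this ring would read.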